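Methyl to Cyano on the Amide Aryl Ring

A few compounds are considered here, and "the series" means these few. Any claim that something is new, unique, unknown or untested is made for them only; others in the source may bear on it.

Compound 1, `CCC(=O)Nc1c(C(O)(C(F)(F)F)C(F)(F)F)ccc2ccccc12`: 8.91 nM
Compound 2, `C/C=C/C(=O)Nc1c(C(O)(C(F)(F)F)C(F)(F)F)ccc2ccccc12`: 49 nM
Compound 3, `Cc1cccc(C(=O)Nc2c(C(O)(C(F)(F)F)C(F)(F)F)ccc3ccccc23)c1`: 52.5 nM

The three compounds share one core and differ only in the group attached to the carbonyl carbon of the amide. In a functional assay (Sus scrofa) with sulfonylurea receptors; K-ATP channels (Homo sapiens) as the target (a lower number here means that less compound is needed, a higher number that more compound is needed for the effect), compound 1 gives 8.91 nM, and both larger groups need more compound: a 5.5-fold higher number from compound 1 to compound 2 (0.74 log units; beyond the scatter) and a 5.9-fold higher number from compound 1 to compound 3 (0.77 log units; beyond the scatter). Compound 3 cannot be separated from compound 2 by this assay, since a 1.1-fold higher number from compound 2 to compound 3 (0.03 log units; within the scatter).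

Compound 4, `N#Cc1cccc(C(=O)Nc2c(C(O)(C(F)(F)F)C(F)(F)F)ccc3ccccc23)c1`, keeps the aryl amide of compound 3 and changes one group on its ring: cyano in place of methyl on an aromatic carbon. Going by the values given here, no measured step alters a substituent on that ring; every measured step exchanges the whole group on the carbonyl carbon, and the one step between two larger groups, a 1.1-fold higher number from compound 2 to compound 3 (0.03 log units; within the scatter), stays within the scatter. The data therefore give no ground for a directional change, and the expected step is small, a 1.1-fold lower number from compound 3 to compound 4 (0.02 log units; within the scatter). Compound 4 is estimated at 50 nM, with a range from 15 nM to 160 nM.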

Compound 4, half-maximal effective concentration: 372 nM
Beside the measured number, compound 4's estimate is 7.4-fold (0.87 log units) below it, and the stated range ends below it.
By their numbers in this assay, from the lowest: compound 1; then compounds 2 and 3 (each within the scatter of the next); then compound 4.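

Until now every step exchanged the whole group on the carbonyl carbon, so a change on the aryl ring itself had not been tested; in this assay one group on that ring proves enough to matter (a 7.1-fold higher number from compound 3 to compound 4 (0.85 log units; beyond the scatter)). Compound 3 could not be separated from compound 2, but the cyano group opens a gap to the prop-1-en-1-yl amide (a 7.6-fold higher number from compound 2 to compound 4 (0.88 log units; beyond the scatter)) and widens the distance to the ethyl amide into a large one (a 42-fold higher number from compound 1 to compound 4 (1.62 log units; beyond the scatter)). Nothing in the available data explains this step.

From the compounds shown here alone, whether the higher number is particular to cyano or would follow other replacements of methyl stays open, and a chloro, methoxy or amino group on the same ring carbon could help to tell. Also open, going by these compounds, is how cyano would read on a different carbon of this ring.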